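A few compounds are considered here, and "the series" means these few. Any claim that something is new, unique, unknown or untested is made for them only; others in the source may bear on it.

Compound 1 `c1ccc(C[C@H](CCn2cncn2)c2ccccc2)cc1` gives 55.4 ug/mL in an ADME assay on RD cells (Homo sapiens) for cytotoxicity, read by MTT assay, with a stated time of 3 days; a lower number here means that less compound is tolerated, a higher number that more compound is tolerated.
Compound 2 `c1ccc(C[C@@H](CCn2cncn2)c2ccccc2)cc1` gives 56 ug/mL in this assay.
Compound 3 `Cc1ccc([C@@H](CCn2cncn2)Cc2ccccc2)cc1` gives 109 ug/mL in this assay.

Compound 1 stands lowest of the three numbers, but its neighbours are close: compound 2, which differs only in configuration as drawn, lies within the scatter at a 1.0-fold higher number from compound 1 to compound 2 (0.00 log units; within the scatter), and compound 3 lies at a 2.0-fold higher number from compound 1 to compound 3 (0.29 log units; within the scatter), also within the scatter. The step under consideration leads to compound 4 `Cc1ccc(C[C@H](CCn2cncn2)c2ccccc2)cc1`, in which (methyl in place of hydrogen on an aromatic carbon). Within the data shown here, of the measured steps, the one from compound 1 to compound 3 bears on it most directly, since it is likewise methyl in place of hydrogen on an aromatic carbon and came to a 2.0-fold higher number from compound 1 to compound 3 (0.29 log units; within the scatter). The step from compound 1 to compound 2, a change of configuration alone, bears on it little. One therefore expects for compound 4 in this assay a step of about that small size, upward if at all, and nothing beyond the scatter: a 1.4-fold higher number from compound 1 to compound 4 (0.16 log units; within the scatter). The estimate for compound 4 is 80 ug/mL, within 45 ug/mL to 140 ug/mL.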

Compound 4, half-maximal cytotoxic concentration: 37.8 ug/mL
Beside the measured number, compound 4's estimate is 2.1-fold (0.33 log units) above it; measured number outside the range, below it.
By their numbers in this assay, from the lowest: compounds 4, 1, 2 and 3 (each within the scatter of the next, the first and the last beyond it).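

In this assay, the change from phenyl to 4-methylphenyl on this ring gives a 1.5-fold lower number from compound 1 to compound 4 (0.17 log units; within the scatter). Together with a 2.0-fold higher number from compound 1 to compound 3 (0.29 log units; within the scatter), which places the same methyl on the other aromatic ring of compound 1, this shows that a methyl para to a large group leaves the number within the scatter on either ring, so neither step sets a direction for this change. Nothing given here offers a cause for the result at this position. The compounds shown leave open whether a larger or different group at this place, such as methoxy, chlorine or an amine, would move the number beyond the scatter. They also leave open whether configuration still makes no difference once the methyl is present, since only compounds 1 and 2 form such a pair.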